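The source may report more compounds than this note shows. Statements on the series, on what has been measured and on what is new or still open speak of the compounds shown alone.

Measured so far:
compound 1 `CCCCC(C)(C)[C@H](O)/C=C/[C@H]1CCC(=O)N1CCSc1nc(C(=O)O)cs1` — 4.2 nM
compound 2 `CC(C)(C)CCC1([C@H](O)/C=C/[C@H]2COC(=O)N2CCSc2nc(C(=O)O)cs2)CCC1` — 4710 nM
compound 3 `CC(C)(CCCCF)[C@H](O)/C=C/[C@H]1COC(=O)N1CCSc1nc(C(=O)O)cs1` — 1220 nM

In an assay on isolated protein for agonist activity at prostaglandin E2 receptor EP4 subtype (Homo sapiens) (on this read-out lower numbers stand for an effect already at smaller amounts and higher numbers for an effect only at larger amounts of compound), compound 2 gives the highest of the three numbers. Its nearest neighbour is compound 3, reached by the step of a 3.9-fold lower number from compound 2 to compound 3 (0.59 log units; beyond the scatter), in which the whole substituted ring on the chain carbon carrying the hydroxyl is exchanged for an open chain. Going by the values given here, compound 1, with a different core, gives a far lower number, but the two structures differ in more than one place and no single step between them is given.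

Compound 4 `O=C(O)c1csc(SCCN2C(=O)OC[C@@H]2/C=C/[C@@H](O)C2(CCc3ccccc3)CCC2)n1` is to be measured in this assay. It differs from compound 2 by phenyl in place of tert-butyl on a saturated chain carbon, two bonds along the chain from a saturated ring carbon — read one bond further out, neopentyl becomes benzyl and 3,3-dimethylbutyl becomes phenethyl. Among the compounds with values here, no measured step touches this terminus alone; the only step starting from compound 2 alters the ring as well as the chain. The expectation therefore rests on the size of that step: a change of comparable order, most likely toward a lower number, with the direction not secured by the data.

Compound 4 is expected to give 1500 nM in this assay, within 300 nM to 8000 nM, which would mean an estimated step of a 3.1-fold lower number from compound 2 to compound 4 (0.50 log units; beyond the scatter).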

Compound 4, half-maximal effective concentration: 465 nM
Compound 4: middle estimate off by 3.2-fold (0.51 log units), on the high side; the measured number falls inside the stated range.
By their numbers in this assay, from the lowest: compound 1; then compound 4; then compound 3; then compound 2.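

In this assay the exchange of tert-butyl for phenyl gives a 10-fold lower number from compound 2 to compound 4 (1.01 log units; beyond the scatter), a large step and the first one in the series that changes this terminus alone. The step of a 3.9-fold lower number from compound 2 to compound 3 (0.59 log units; beyond the scatter) altered the ring as well as the chain, so it could not separate the two; here the ring on the chain carbon carrying the hydroxyl stays in place, and a change on a saturated chain carbon, two bonds along the chain from a saturated ring carbon, is enough to move the number beyond the scatter. Nothing at hand gives a reason for this step, whether the aromatic ring or the change in heavy atoms is what counts..

Open, going by these compounds, is whether a pyridine ring, a methoxy group or a fluorine on the phenyl, or a longer chain leading to it, would carry the step further or reverse it. Also open, on these data alone, is whether phenyl at this terminus would have any comparable effect on the core of compound 1, which gives 4.2 nM with a different chain and core.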